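A few compounds are considered here, and "the series" means these few. Any claim that something is new, unique, unknown or untested is made for them only; others in the source may bear on it.

Measured in a functional assay on HEK293 cells for positive allosteric modulation of metabotropic glutamate receptor 5 (Homo sapiens), read by calcium flux; on this read-out lower numbers stand for smaller maximal responses and higher numbers for larger maximal responses:
compound 1, `O=C1c2cc(COc3ccccn3)nn2CCN1c1ccc(F)cc1`, 68%
compound 2, `O=C1c2cc(COc3ccc(F)cn3)nn2CCN1c1ccc(F)cc1`, 52%

Compound 1 holds the highest of the two numbers shown. Among the compounds with values here, its nearest neighbour is compound 2, and the only measured step, a number 16 percentage points lower from compound 1 to compound 2 (beyond the scatter), comes with fluoro in place of hydrogen on an aromatic carbon.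

Compound 3, `O=C1c2cc(OCc3ccccc3)nn2CCN1c1ccc(F)cc1`, has not yet been measured in this assay. Against compound 1 it differs in one place: benzyloxy in place of ((pyridin-2-yl)oxy)methyl on an aromatic carbon. Within the data shown here, no measured step bears on this change; the single step recorded concerns a fluoro on the pyridine ring, which is not what changes here. The data therefore give no direction for this exchange, and the expectation rests on compound 1 alone, with a range wide enough to allow a modest step either way.

Compound 3 is accordingly estimated at 60%, with a range from 40% to 80%, which means an expected step of a number 8 percentage points lower from compound 1 to compound 3 (within the scatter).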

Compound 3, largest response reached (Emax), in percent of the reference or control that the assay uses: 54%
Estimate against measurement, compound 3: 6 percentage points above; the measured number falls inside the stated range.
By their numbers in this assay, from the lowest: compounds 2 and 3 (each within the scatter of the next); then compound 1.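

In this assay the step of a number 14 percentage points lower from compound 1 to compound 3 (beyond the scatter) comes with benzyloxy in place of ((pyridin-2-yl)oxy)methyl, which shows that the maximal response also depends on the group on this aromatic carbon of the five-membered ring, and not only on a fluoro on the pyridine ring. The exchange keeps the count of 8 heavy atoms and one six-membered aromatic ring, yet the number still moves beyond the scatter as the ring nitrogen goes and the hydrogen-bond acceptors fall from 2 to 1. No measurement at hand gives a reason for this step.

The compounds shown leave open whether the step follows the loss of the ring nitrogen or the changed order of oxygen and carbon in the link. Also open, on these data alone, is how an amine or a longer alkyl chain would fare at this carbon.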